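A Fluorine and a Methyl Replace the Methoxy Group

The compounds below may be only part of what the source reports. "The series", "measured", "known", "first", "only" and "open" are said of these compounds alone.

Compound 2 `COc1ccc(-c2cc(Cl)cc(Cl)c2/C=C/[C@@H]2C[C@@H](O)CC(=O)O2)cc1` stands highest of the two numbers recorded in an assay for inhibition of 3-hydroxy-3-methylglutaryl-coenzyme A reductase (Rattus norvegicus) (on this read-out lower numbers stand for stronger inhibition and higher numbers for weaker inhibition), where compound 2 gives 470 nM. Going by the values given here, its only neighbour, compound 1 `Cc1cccc(-c2cc(Cl)cc(Cl)c2/C=C/[C@@H]2C[C@@H](O)CC(=O)O2)c1`, gives 16 nM in this assay, and the change a 29-fold higher number from compound 1 to compound 2 (1.47 log units; beyond the scatter) is the single measured step available. Compound 3 `Cc1cc(-c2cc(Cl)cc(Cl)c2/C=C/[C@@H]2C[C@@H](O)CC(=O)O2)ccc1F` follows from compound 2 by the change (4-fluoro-3-methylphenyl in place of 4-methoxyphenyl on an aromatic carbon). This removes the methoxy group of compound 2, brings in a fluorine, and restores the methyl group that compound 1 carries. Among the compounds with values here, no measured pair mirrors this change exactly; the step that bears on it is a 29-fold higher number from compound 1 to compound 2 (1.47 log units; beyond the scatter), which shows how costly the 4-methoxyphenyl was against the 3-methylphenyl. For compound 3 the expected step in this assay is therefore a 12-fold lower number from compound 2 to compound 3 (1.07 log units; beyond the scatter), toward the stronger side. The estimate for compound 3 is 40 nM, with a range from 10 nM to 160 nM.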

Compound 3, half-maximal inhibitory concentration: 29 nM
Estimate against measurement, compound 3: 1.4-fold (0.14 log units) above; measured number inside the range.
By their numbers in this assay, from the lowest: compounds 1 and 3 (each within the scatter of the next); then compound 2.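

In this assay the change shows a large recovery, with a 16-fold lower number from compound 2 to compound 3 (1.21 log units; beyond the scatter) as its size, so the cost of the 4-methoxyphenyl does not extend to every substituted phenyl at this aromatic carbon. The fluoro step, a 1.8-fold higher number from compound 1 to compound 3 (0.26 log units; within the scatter) in size, stays within the scatter, so the 4-fluoro-3-methylphenyl group and the methyl-bearing ring of compound 1 cannot be told apart on this read-out. No measurement shown here gives a reason for the gap between the methoxy-bearing and the fluoro-bearing rings.

The step to compound 3 changes two things at once, so the compounds shown do not separate the loss of the methoxy group from the arrival of the methyl group. As far as these compounds go, how a 4-methylphenyl, a 3-methoxyphenyl or a phenyl ring carrying an amine or a carboxylic acid would read remains open.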